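The compounds below may be only part of what the source reports. "The series", "measured", "known", "first", "only" and "open" are said of these compounds alone.

Of the compounds shown here, three built on a shared core have been measured in a functional assay on Ehrlich cells (Mus musculus) for inhibition; on this read-out higher numbers stand for weaker inhibition and lower numbers for stronger inhibition. Compound 1 `CN(C)c1ccc2c(O)c(C(=O)O)cnc2c1` gives 468000 nM. Compound 2 `O=C(O)c1cnc2cc(O)ccc2c1O` gives 912000 nM. Compound 3 `CC(=O)c1ccc2c(O)c(C(=O)O)cnc2c1` gives 794000 nM. Compound 3 stands second highest of the three numbers; the nearest step to it is a 1.1-fold lower number from compound 2 to compound 3 (0.06 log units; within the scatter) and the furthest is a 1.7-fold higher number from compound 1 to compound 3 (0.23 log units; within the scatter), both within the scatter, so no order among the three can be claimed.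

Compound 4 `O=C(O)c1cnc2cc(F)ccc2c1O` differs from compound 3 in one place: fluoro in place of acetyl on an aromatic carbon. Every step measured so far likewise swaps one group on an aromatic carbon, and none moved the number beyond the scatter: a 1.9-fold higher number from compound 1 to compound 2 (0.29 log units; within the scatter), a 1.7-fold higher number from compound 1 to compound 3 (0.23 log units; within the scatter) and a 1.1-fold lower number from compound 2 to compound 3 (0.06 log units; within the scatter). Among the measured compounds shown here, no measured step involves fluoro, so the only ground for an expectation is that three rather different groups at this place gave numbers within the scatter of one another. The expected step is therefore a 1.0-fold higher number from compound 3 to compound 4 (0.00 log units; within the scatter), not beyond the scatter in either direction. Compound 4 is expected to give 800000 nM in this assay, with a range from 300000 nM to 2000000 nM to allow for the scatter and for the lack of any measured step with fluoro.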

Compound 4, half-maximal inhibitory concentration: 501000 nM
Compound 4: middle estimate off by 1.6-fold (0.20 log units), on the high side; the range from low to high includes it.
By their numbers in this assay, from the lowest: compounds 1, 4, 3 and 2 (each within the scatter of the next).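

Fluoro is a fourth kind of group at this aromatic carbon in this assay, and the steps that reach it, a 1.6-fold lower number from compound 3 to compound 4 (0.20 log units; within the scatter) and a 1.8-fold lower number from compound 2 to compound 4 (0.26 log units; within the scatter) and a 1.1-fold higher number from compound 1 to compound 4 (0.03 log units; within the scatter), all lie within the scatter. The change from acetyl is the clearest test so far of what this place tolerates: 3 heavy atoms, a double bond and a hydrogen-bond acceptor leave, a single fluorine enters, and the two numbers still cannot be told apart. With four different groups now giving numbers within the scatter of their neighbours, the read-out shows no measurable response to the group at this place among these compounds, and no measurement at hand offers an explanation for this.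

Going by these compounds, whether a longer chain, a primary amine or an amide at this aromatic carbon would carry the number beyond the scatter remains open. Also open is what happens when the carboxylic acid or the hydroxy shared by all four compounds is replaced, for instance by an ester or a methoxy group, since every step shown leaves both in place.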